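The source may hold more compounds than are shown below. What is called first, only, known or untested is meant among the compounds shown, and "the series" means these compounds.

Compound 1 `O=C(CCCc1cn(Cc2ccccc2)c2ccccc12)NC1CCCCCC1`: "not determined" (no result reported)
Compound 2 `Cc1ccc(S(=O)(=O)n2cc(CCCC(=O)NC3CCCCCC3)c3ccccc32)cc1`: > 250000 nM
Compound 3 `CC(C)(C)c1ccc(S(=O)(=O)n2cc(CCCC(=O)NC3CCCCCC3)c3ccccc32)cc1`: > 250000 nM

These results come from an ADME assay on Vero cells (Chlorocebus sabaeus) for cytotoxicity, read by fluorescence and resazurin assay, with a stated time of 3 days; on this read-out lower numbers stand for higher toxicity in this test and higher numbers for lower toxicity in this test. Compound 3 stands at > 250000 nM, which is a limit of the assay and not a number. Compound 2 also gives only a limit, with > 250000 nM. Compound 1 offers no number for comparison. The record therefore holds (the limit of > 250000 nM in this assay, at which 2 of the 3 values shown sit).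

Compound 4 `O=C(CCCc1cn(S(=O)(=O)c2cccc3ccccc23)c2ccccc12)NC1CCCCCC1` is the next case, and it differs from compound 3 by naphthalen-1-yl in place of 4-(tert-butyl)phenyl on a sulfonyl sulfur. In words, naphthalen-1-yl takes the place of 4-(tert-butyl)phenyl on a sulfonyl sulfur. Within the data shown here, the one measured step that bears on this change is a step that the two limits leave unreadable from compound 2 to compound 3. That step also concerns the group carried on the sulfonyl sulfur, but it gives no size to carry forward, and neither does it give a direction.

Because of the limit of > 250000 nM in this assay, at which 2 of the 3 values shown sit, compound 4 is expected to remain close to that limit in this assay, and it may well be reported only as a limit again. The estimate amounts to an at least 1.0-fold lower number from compound 3 to compound 4 (0.03 log units; that floor lies within the scatter), which is expected to lie within the usual scatter. For compound 4 the estimated value is 230000 nM, with an expected range from 90000 nM to 250000 nM.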

Compound 4, half-maximal cytotoxic concentration: > 250000 nM
Compound 4 was reported as a limit; the forecaster's own chance of this, stated with the estimate: 70%; middle value at least 1.0-fold (0.03 log units) away from the limit.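

Compound 4 is again reported only as a limit of the assay in this assay, at > 250000 nM. No step among compound 2, compound 3 and compound 4 can be read, because all three sit at that limit: the limit of > 250000 nM in this assay, at which 3 of the 4 values shown sit.

The compounds shown leave open whether the groups on the sulfonyl sulfur differ at all on this read-out.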